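The source may hold more compounds than are shown below. What is called first, only, known or untested is meant among the compounds shown, and "the series" means these compounds.

Three measured compounds share one core; compound 1 `O=c1n(Cc2nc3ccc(F)cn3c2CCCCO)c2cnccc2n1C1CC1`, compound 2 `O=c1n(Cc2nc3cc(C(F)(F)F)ccn3c2CCCCO)c2cnccc2n1C1CC1` and compound 3 `O=c1n(Cc2nc3cc(Cl)ccn3c2CO)c2cnccc2n1C1CC1` differ in the group on the fused ring system and in the side chain carried there. In an ADME assay on HEp-2 cells (Homo sapiens) for cytotoxicity, read by CCK-8 assay, with a stated time of 6 days (on this read-out higher numbers stand for lower toxicity in this test and lower numbers for higher toxicity in this test), compound 1 gives > 100000 nM, which is a limit of the assay and not a number. In this assay compound 2 gives > 100000 nM, again a limit rather than a number. In this assay compound 3 gives > 100000 nM, also a limit of the assay. Compound 3 thus stands with the other two at the limit, as summed up by the limit of > 100000 nM in this assay, at which 3 of the 3 values shown sit; the numbers shown do not separate any of the three.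

Compound 4 `O=C(O)/C=C/c1c(Cn2c(=O)n(C3CC3)c3ccncc32)nc2cc(Cl)ccn12` has not yet been measured in this assay. It differs from compound 3 in one place: 2-carboxyethenyl in place of hydroxymethyl on an aromatic carbon. No step between measured compounds is shown in this assay, so there is nothing to scale the change against; every value shown sits at the limit, and no change beyond the scatter is expected from compound 3 to compound 4 in this assay. The expected step is accordingly flat, a number no higher from compound 3 to compound 4 (the limit leaves the size open). Compound 4 is expected to give 100000 nM in this assay, within a range from 50000 nM to 200000 nM, and most probably to be reported again only as a limit.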

Compound 4, half-maximal cytotoxic concentration: > 100000 nM
Compound 4 gave a limit, no number; the forecaster's own chance of this, stated with the estimate: 80%; the middle value lies on the limit itself.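

Among the compounds shown here, compound 3 and compound 4 both give only a limit in this assay, so no step from one to the other can be read: the limit of > 100000 nM in this assay, at which 4 of the 4 values shown sit.

The compounds shown leave open whether 2-carboxyethenyl in place of hydroxymethyl changes the read-out at all, and which change to the shared core or its side chain would give a readable number in this assay.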